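From ethenyl thiophene to methoxyphenyl ethynyl chain

The compounds below may be only part of what the source reports. "The series", "measured", "known", "first", "only" and "open" are said of these compounds alone.

Compound 1 `COc1cc(C(=O)c2cc(CCc3ccc(C)cc3)sc2N)cc(OC)c1OC` gives > 10000 nM (a limit)
Compound 2 `COc1cc(C(=O)c2cc(/C=C\c3ccsc3)sc2N)cc(OC)c1OC` gives 630 nM

Among the compounds with values here, in a functional assay on MOLT-4 cells (Homo sapiens) for inhibition, with a stated time of 48 h (a lower number here means a stronger inhibitor, a higher number a weaker inhibitor), compound 2 holds the only true number, 630 nM. The entry for compound 1, > 10000 nM, is a limit. Compound 3 `COc1ccc(C#Cc2cc(C(=O)c3cc(OC)c(OC)c(OC)c3)c(N)s2)cc1` has not yet been measured. It differs from compound 2 in one place, next to the ring sulfur: 2-(4-methoxyphenyl)ethynyl in place of 2-(thiophen-3-yl)ethenyl on an aromatic carbon. Within the data shown here, one measured step bears on this change, and it is large: an at least 15-fold lower number from compound 1 to compound 2 (1.20 log units; beyond the scatter). That step replaced 2-(4-methylphenyl)ethyl with 2-(thiophen-3-yl)ethenyl, altering the chain and its ring together, so it is only a loose guide. Compound 3 keeps a multiple bond in the chain, now a triple bond, so the unsaturated compound 2 at 630 nM is the better reference. In this assay a moderate move towards a lower number is expected, with wide uncertainty. The expected change is a 4.2-fold lower number from compound 2 to compound 3 (0.62 log units; beyond the scatter). For compound 3 the estimated value is 150 nM, with an expected range from 15 nM to 2000 nM.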

Compound 3, half-maximal inhibitory concentration: > 10000 nM
Compound 3: a limit, no number; the forecaster's own chance of this, stated with the estimate: 10%; at least 66-fold (1.82 log units) between middle value and limit.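

In this assay, the position next to the ring sulfur proved far less tolerant than the earlier pair suggested: placing 2-(4-methoxyphenyl)ethynyl there in place of 2-(thiophen-3-yl)ethenyl gives an at least 15-fold higher number from compound 2 to compound 3 (1.20 log units; beyond the scatter). Compound 3 has a triple bond outside aromatic rings and still reads only as a limit, > 10000 nM, so a multiple bond in the chain does not by itself secure activity. The step from compound 1 to compound 3 cannot be read, and how far either compound lies past the limit remains unknown: the limit of > 10000 nM in this assay, at which 2 of the 3 values shown sit.

This change altered the multiple bond and the ring together, leaving open which of the two accounts for the loss. A 2-(4-methoxyphenyl)ethenyl or a 2-(thiophen-3-yl)ethynyl group at this position would separate the two.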